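From Methoxy to Ethoxy in a Growth Assay

This account rests on a few compounds, and the source may have more. Where it says the series, first, only, none or still open, it means among the compounds named here.

Among the compounds with values here, in a functional assay on KM12 cells (Homo sapiens) for antiproliferative activity (a lower number here means a stronger inhibitor of growth, a higher number a weaker inhibitor of growth), compound 2 `COc1ccc(-c2nc3cc(F)ccc3s2)cc1OC` gives 290 nM, the lower of the two numbers measured so far. The other, compound 1 `COc1ccc(-c2nc3cc(F)ccc3s2)cc1F`, gives 20600 nM. Within the data shown here, the one measured step, a 71-fold lower number from compound 1 to compound 2 (1.85 log units; beyond the scatter), puts methoxy in place of fluoro on an aromatic carbon, and it is large. Compound 3 `CCOc1cc(-c2nc3cc(F)ccc3s2)ccc1OC` extends that same methoxy to ethoxy: methyl in place of hydrogen on a saturated chain carbon bound to an oxygen on an aromatic ring. Among the measured compounds shown here, no measured step covers this change directly, but a 71-fold lower number from compound 1 to compound 2 (1.85 log units; beyond the scatter) shows that the read-out can respond strongly to a change at that carbon. A moderately higher number is therefore expected, though the direction is uncertain. The estimated change is a 2.4-fold higher number from compound 2 to compound 3 (0.38 log units; beyond the scatter). Compound 3 is estimated at 700 nM, with an expected range of 150 nM to 4000 nM.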

Compound 3, concentration for 50% growth inhibition: 5420 nM
Compound 3: middle estimate off by 7.7-fold (0.89 log units), on the low side; the measured number lies above the stated range.
By their numbers in this assay, from the lowest: compound 2; then compound 3; then compound 1.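

The added methyl shows that this position responds not only to what replaces fluoro on the aromatic carbon, but also to the chain carried on that oxygen: in this assay, going from methoxy to ethoxy gives a 19-fold higher number from compound 2 to compound 3 (1.27 log units; beyond the scatter) and gives back most of the gain that methoxy brought. Ethoxy still keeps part of that gain, with a 3.8-fold lower number from compound 1 to compound 3 (0.58 log units; beyond the scatter) as a modest step, so among these three compounds methoxy gives the lowest number and fluoro the highest. No evidence is available on what lies behind this sharp response to a single methyl.

The compounds shown leave open whether a longer chain such as propoxy would raise the number further. They also leave open how a hydroxyl or an amine in this place would compare with methoxy.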